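The compounds below may be only part of what the source reports. "The series", "measured", "known", "first", "only" and "open" are said of these compounds alone.

Compound 1, `O=c1c2c(Nc3ccccc3)nn(-c3ccc([N+](=O)[O-])cc3)c2nc(Nc2ccccc2)n1-c1ccccc1`, and compound 2, `NS(=O)(=O)c1ccc(-n2nc(Nc3ccccc3)c3c(=O)n(-c4ccccc4)c(Nc4ccccc4)nc32)cc1`, share a core and differ only at one aromatic carbon, where (sulfamoyl in place of nitro on an aromatic carbon). In a functional assay on the whole organism (strain Wistar albino) for inhibition, with Rattus norvegicus as the target, read by paw edema, with a stated time of 3 h, at a dose of 25 mg/kg by the oral route (a higher number here means more inhibition at the dose given (going by the name of the read-out), a lower number less inhibition), compound 1 gives 14.1%, and compound 2 gives 39.7%, so that a number 25.6 percentage points higher from compound 1 to compound 2 (beyond the scatter).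

Compound 3, `O=c1c2c(Nc3ccc(Cl)cc3)nn(-c3ccc([N+](=O)[O-])cc3)c2nc(Nc2ccccc2)n1-c1ccccc1`, carries the same core as compound 1 except that (chloro in place of hydrogen on an aromatic carbon). In this assay compound 3 gives 20.6%; a number 6.5 percentage points higher from compound 1 to compound 3 (within the scatter).

Compound 4, `NS(=O)(=O)c1ccc(-n2nc(Nc3ccc(Cl)cc3)c3c(=O)n(-c4ccccc4)c(Nc4ccccc4)nc32)cc1`, has not yet been measured. It stands to compound 3 as compound 2 stands to compound 1: sulfamoyl in place of nitro on an aromatic carbon. The place of the change is described in the same words for both pairs, so it is the same change, made on a core that differs by the chloro group just described.

From one example alone, the expectation is that the change will act on compound 3 much as it did on compound 1, because a number 25.6 percentage points higher from compound 1 to compound 2 (beyond the scatter). Compound 4 is therefore expected to give about 46% in this assay, between 30% and 60%, which would mean a number 25.4 percentage points higher from compound 3 to compound 4 (beyond the scatter).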

Compound 4, a percentage reported as inhibition, in the whole organism at one dose (the size of the read-out at that dose, not a potency): 38.3%
Compound 4: middle estimate off by 7.7 percentage points, on the high side; the range from low to high includes it.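

In this assay, for the compounds shown here, sulfamoyl in place of nitro on the core carrying the chloro group gives a number 17.7 percentage points higher from compound 3 to compound 4 (beyond the scatter), and the change carries over from one core to the other with no gap beyond the scatter: the same change on two cores in this assay, a number 25.6 percentage points higher (beyond the scatter) from compound 1 to compound 2 and a number 17.7 percentage points higher (beyond the scatter) from compound 3 to compound 4, 7.9 percentage points apart, within the scatter of two such steps The chloro group, set on the core bearing sulfamoyl, gives a number 1.4 percentage points lower from compound 2 to compound 4 (within the scatter), and on neither core does it move the number beyond the scatter: the same change on two cores in this assay, a number 6.5 percentage points higher (within the scatter) from compound 1 to compound 3 and a number 1.4 percentage points lower (within the scatter) from compound 2 to compound 4, 7.9 percentage points apart, within the scatter of two such steps This covers only two cores that differ by a single chloro group, read at one dose and one time, so it does not show that the step would hold on cores changed elsewhere, nor why sulfamoyl reads higher than nitro.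

The compounds shown leave open how an amine or a carboxylic acid would read in the place of the sulfamoyl. They also leave open whether a methoxy or a methyl group in the place of the chloro would alter the size of the step.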